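Substituent at the ring amide nitrogen: expectation for compound 4

The source may hold more compounds than are shown below. What is called first, only, known or untested is meant among the compounds shown, and "the series" means these compounds.

Compound 1 `COC(=O)/C=C/c1ccc2c(c1)C(=O)C(=O)N2C` is the reference point. For the measured compounds named here, in a functional assay on Jurkat cells (Homo sapiens) for antiproliferative activity, read by MTT assay, with a stated time of 48 h (on this read-out lower numbers stand for stronger inhibition and higher numbers for weaker inhibition), compound 1 gives 250 nM, the second highest of the three numbers so far. Compound 2 `CCN1C(=O)C(=O)c2cc(/C=C/C(=O)OC)ccc21` gives 200 nM in this assay, and compound 3 `COC(=O)/C=C/c1ccc2c(c1)C(=O)C(=O)N2Cc1ccc(C(F)(F)F)cc1` gives 360 nM; all three numbers lie within the scatter of one another, so no ordering among them can be stated.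

The change to compound 4 `COC(=O)/C=C/c1ccc2c(c1)C(=O)C(=O)N2Cc1ccc(C)cc1` is 4-methylphenyl in place of hydrogen on a saturated chain carbon bound to an amide-type nitrogen in a ring. Going by the values given here, the one step measured at this position, a 1.3-fold lower number from compound 1 to compound 2 (0.10 log units; within the scatter), is small and within the scatter. Compound 3 carries a larger group at the same place and its number, against that of compound 1, again shows no difference beyond the scatter. Among the compounds with values here, nothing among the measured compounds points to a shift in either direction, so no step beyond the scatter is expected in this assay: the step from compound 1 to compound 4 is estimated as a 1.2-fold higher number from compound 1 to compound 4 (0.08 log units; within the scatter). Compound 4 is therefore expected to give about 300 nM, with a likely range from 120 nM to 750 nM.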

Compound 4, half-maximal inhibitory concentration: 50 nM
The estimate for compound 4 lay 6.0-fold (0.78 log units) above the measured number; measured number below the stated range.
By their numbers in this assay, from the lowest: compound 4; then compounds 2, 1 and 3 (each within the scatter of the next).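

In this assay the substituent on the amide-type nitrogen in a ring now registers: 4-methylphenyl in place of hydrogen on the saturated chain carbon gives a 5.0-fold lower number from compound 1 to compound 4 (0.70 log units; beyond the scatter) and 4-methylphenyl in place of methyl there gives a 4.0-fold lower number from compound 2 to compound 4 (0.60 log units; beyond the scatter) whereas the earlier step at this place stayed within the scatter. The aromatic ring alone does not bring the lower number, as methyl in place of trifluoromethyl on an aromatic carbon gives a 7.2-fold lower number from compound 3 to compound 4 (0.86 log units; beyond the scatter) and so the group on that ring also counts. Nothing measured on these compounds gives a reason for this difference.

Open, from the compounds shown here alone, is whether plain benzyl, with no group on the ring, falls with compound 4 or with compound 3. Also open, going by these compounds, is whether an amine or a carboxylic acid in place of that methyl, or a longer chain carrying the ring, keeps the lower number.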